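The source may report more compounds than this note shows. Statements on the series, on what has been measured and on what is new or still open speak of the compounds shown alone.

Compound 3 `COc1cc(-n2cnc3ccc(-c4ccccc4Cl)cc32)cc(OC)c1OC` in a functional assay on A549 cells (Homo sapiens) for antiproliferative activity, read by MTT assay, with a stated time of 72 h (on this read-out higher numbers stand for weaker inhibition and lower numbers for stronger inhibition), reaches only a limit of the assay, > 10000 nM. Compound 1 `COc1cc(-n2cnc3ccc(-c4ccc(Cl)cc4)cc32)cc(OC)c1OC` likewise stops at a limit in this assay, > 10000 nM. Among the compounds with values here, compound 2 `COc1cccc(-c2ccc3ncn(-c4cc(OC)c(OC)c(OC)c4)c3c2)c1` is the single member with a number, giving 3180 nM in this assay. Because of the limit of > 10000 nM in this assay, at which 2 of the 3 values shown sit, the step that the two limits leave unreadable from compound 1 to compound 3 cannot be read, whereas an at least 3.1-fold higher number from compound 2 to compound 3 (0.49 log units; beyond the scatter) and an at least 3.1-fold lower number from compound 1 to compound 2 (0.49 log units; beyond the scatter) both mark 3-methoxyphenyl as the strongest of the three groups tried at this carbon. Compound 4 `COc1ccc(-c2ccc3ncn(-c4cc(OC)c(OC)c(OC)c4)c3c2)cc1F` is not yet measured; the change 3-fluoro-4-methoxyphenyl in place of 2-chlorophenyl on an aromatic carbon again removes the 2-chlorophenyl, and the entering group carries a methoxy, as the group in compound 2 does. The step of an at least 3.1-fold higher number from compound 2 to compound 3 (0.49 log units; beyond the scatter) bears most directly on it, read in reverse, though its size is only a bound. The expected step of an at least 2.5-fold lower number from compound 3 to compound 4 (0.39 log units; beyond the scatter) is therefore a move back down toward the region of compound 2. Compound 4 is estimated at 4000 nM, with a range from 1500 nM to 10000 nM. A limit remains a real possibility.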

Compound 4, half-maximal inhibitory concentration: 1430 nM
Beside the measured number, compound 4's estimate is 2.8-fold (0.45 log units) above it; measured number below the stated range.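

In this assay, a further gain appears at this carbon among the groups carrying a methoxy, with a 2.2-fold lower number from compound 2 to compound 4 (0.35 log units; beyond the scatter), which makes 3-fluoro-4-methoxyphenyl the strongest of the four groups shown. Against the two chlorophenyl groups the gain is an at least 6.9-fold lower number from compound 3 to compound 4 (0.84 log units; beyond the scatter) and an at least 6.9-fold lower number from compound 1 to compound 4 (0.84 log units; beyond the scatter), both sizes being bounds only. Both methoxy-bearing groups give numbers and neither chlorophenyl group does, with no compound among the four going against this split, while the step between the two chlorophenyl compounds cannot be read: the limit of > 10000 nM in this assay, at which 2 of the 4 values shown sit.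

Still open, on these data alone, is how much of the gain belongs to the fluorine and how much to where the methoxy stands, as the two differ together. Also open, as far as these compounds go, is whether a methoxy is needed at all, or whether an amine or a carboxylic acid on the phenyl ring would serve.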